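Removing a methoxy group: from compound 2 to compound 4

This account rests on a few compounds, and the source may have more. Where it says the series, first, only, none or still open, it means among the compounds named here.

Results in a functional assay on cells (Panel NCI-60 (60 carcinoma cell lines), Homo sapiens) for inhibition, read by colorimetric assay, with a stated time of 3 days; a lower number here means a stronger inhibitor of growth, a higher number a weaker inhibitor of growth:
Compound 1 `COc1ccc(OC)c(NC(=O)CCCCCCNC(=O)C(O)(O)C(F)(F)F)c1`: "not determined" (no result reported)
Compound 2 `COc1ccc(-c2cnc(NC(=O)CCCCCCNC(=O)C(O)(O)C(F)(F)F)s2)cc1`: 1000 nM
Compound 3 `COc1ccc(NC(=O)CCCCCCNC(=O)C(O)(O)C(F)(F)F)cc1`: "not determined" (no result reported)

Compound 2 is the only one of the three with a number, so it cannot be ranked against the others. Neither compound 1 nor compound 3 offers a result for comparison. Its value therefore serves as a single reference point and shows nothing about how the series behaves.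

The next compound, compound 4 `O=C(CCCCCCNC(=O)C(O)(O)C(F)(F)F)Nc1ncc(-c2ccccc2)s1`, has yet to be measured. It differs from compound 2 in one place: hydrogen in place of methoxy on an aromatic carbon. Hydrogen stands in place of methoxy on an aromatic carbon, para to a large group, so that 4-methoxyphenyl becomes phenyl. The rest of the structure stays the same.

For the measured compounds named here, no pair of measured compounds differs in one place, so the data give no direct precedent for the size or direction of this change. Going by these compounds, with only compound 2 at 1000 nM as a guide, no step beyond the scatter is expected in this assay, and the direction remains open. The expected change is a 1.2-fold higher number from compound 2 to compound 4 (0.08 log units; within the scatter). Compound 4 is estimated at 1200 nM, with an expected range of 400 nM to 3500 nM.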

Compound 4, concentration for 50% growth inhibition: 3020 nM
Beside the measured number, compound 4's estimate is 2.5-fold (0.40 log units) below it, within the range that was stated.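

In this assay the change from 4-methoxyphenyl to phenyl gives a 3.0-fold higher number from compound 2 to compound 4 (0.48 log units; beyond the scatter) and this modest step lies beyond the usual scatter. For the compounds shown here, it is the first comparison between two compounds that differ in one place, and it shows that what stands on this aromatic carbon, para to a large group, can shift the number: with the rest of the structure unchanged, the compound carrying the methoxy group is the stronger inhibitor of growth of the pair. No measurement is available that would explain this difference, so it stands only as an observation on this single pair.

Going by these compounds alone, with only this pair to go on, it remains open whether a chlorine atom, a hydroxyl group or an ethoxy group in the same place would match compound 2, improve on it or fall back towards compound 4. Going by these compounds, it also remains open whether the methoxy group would have a step of similar size and the same direction on a different core, since compound 1 and compound 3 offer no number to compare.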